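Hydroxy for Bromo on the Pendant Phenyl of Compound 3

This account rests on a few compounds, and the source may have more. Where it says the series, first, only, none or still open, it means among the compounds named here.

Compound 3 `COc1cc(-c2cccc3nc(-c4cccc(Br)c4)oc23)cc(OC)c1OC` holds the lowest of the two numbers in a functional assay on NCI-H460 cells (Homo sapiens) for antiproliferative activity, read by MTT assay, with a stated time of 48 h (a higher number here means a weaker inhibitor, a lower number a stronger inhibitor), giving 3800 nM. Compound 2 `COc1cc(-c2cccc3nc(-c4ccc(F)cc4)oc23)cc(OC)c1OC` gives 8700 nM in this assay, and the step of a 2.3-fold lower number from compound 2 to compound 3 (0.36 log units; beyond the scatter) lies beyond the scatter. Compound 1 `COc1ccc(-c2nc3cccc(-c4cc(OC)c(OC)c(OC)c4)c3o2)cc1OC` sits at a limit of the assay, > 25000 nM, in this assay (the limit of > 25000 nM in this assay, at which 1 of the 3 values shown sits). The steps of an at least 2.8-fold lower number from compound 1 to compound 2 (0.45 log units; beyond the scatter) and an at least 6.5-fold lower number from compound 1 to compound 3 (0.81 log units; beyond the scatter) both run from the 3,4-dimethoxyphenyl group toward a halogen-bearing phenyl group and both lower the number.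

Compound 4 `COc1cc(-c2cccc3nc(-c4cccc(O)c4)oc23)cc(OC)c1OC` differs from compound 3 by hydroxy in place of bromo on an aromatic carbon. Going by the values given here, no measured step swaps bromo for hydroxy, so the measured steps bear on it only indirectly: in the steps of an at least 6.5-fold lower number from compound 1 to compound 3 (0.81 log units; beyond the scatter) and a 2.3-fold lower number from compound 2 to compound 3 (0.36 log units; beyond the scatter) the bromo-bearing ring of compound 3 gave the lowest number, while compound 1, which like compound 4 carries oxygen on the pendant ring, gave the weakest result. Compound 4 is therefore expected to give a higher number than compound 3 in this assay, a modest step of a 2.4-fold higher number from compound 3 to compound 4 (0.37 log units; beyond the scatter). The estimate for compound 4 is 9000 nM, with a range from 3000 nM to 30000 nM.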

Compound 4, half-maximal inhibitory concentration: 1900 nM
Compound 4: middle estimate off by 4.7-fold (0.68 log units), on the high side; the measured number lies below the stated range.
By their numbers in this assay, from the lowest: compounds 4 and 3 (each within the scatter of the next); then compound 2. At a limit, above all of these: compound 1.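

In this assay, hydroxy in place of bromo at this place, meta to a large group, gives a 2.0-fold lower number from compound 3 to compound 4 (0.30 log units; within the scatter), so the pendant ring of compound 4 needs no halogen to match compound 3. Oxygen on that ring also proves no mark of a poor result: 3-hydroxyphenyl gives a 4.6-fold lower number from compound 2 to compound 4 (0.66 log units; beyond the scatter) against 4-fluorophenyl and an at least 13-fold lower number from compound 1 to compound 4 (1.11 log units; beyond the scatter) against 3,4-dimethoxyphenyl. Compound 1 stands at a limit of the assay, not at a number: the limit of > 25000 nM in this assay, at which 1 of the 4 values shown sits.

The compounds shown leave open whether a single methoxy, an amine or a carboxylic acid in place of the hydroxy would keep the number of compound 4. They also leave open how hydroxy reads on any other carbon of that ring.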